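Furan-2-yl gives way to furan-3-yl on the carbonyl

The source may report more compounds than this note shows. Statements on the series, on what has been measured and on what is new or still open speak of the compounds shown alone.

Measured in a functional assay on MKN-1 cells (Homo sapiens) for inhibition, read by colorimetric assay and sulforhodamine B assay, with a stated time of 48 h; a higher number here means a weaker inhibitor of growth, a lower number a stronger inhibitor of growth:
compound 1 `CCCCCCCCCCCC[C@@H](O)[C@H]1CC[C@H]([C@H](O)CCCCCCCCCCNC(=O)c2cccs2)O1`: 1820 nM
compound 2 `CCCCCCCCCCCC[C@@H](O)[C@H]1CC[C@H]([C@H](O)CCCCCCCCCCNC(=O)c2ccco2)O1`: 100000 nM

Compound 2, at 100000 nM, holds the higher of the two numbers and is the weaker inhibitor of growth. Compound 3 `CCCCCCCCCCCC[C@@H](O)[C@H]1CC[C@H]([C@H](O)CCCCCCCCCCNC(=O)c2ccoc2)O1` keeps the shared core and differs from it in one place: furan-3-yl in place of furan-2-yl on a carbonyl carbon. This is furan-3-yl in place of furan-2-yl on a carbonyl carbon, with the same atoms joined differently.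

Going by the values given here, only one measured step bears on this change: a 55-fold higher number from compound 1 to compound 2 (1.74 log units; beyond the scatter). That large step, furan-2-yl in place of thiophen-2-yl, shows that this assay can respond strongly to the group at this place. Among the compounds with values here, no measurement yet covers furan-3-yl. With compound 2 at the top of the numbers seen so far, a smaller move toward a lower number is expected, though no change is possible. The expected size is a step of a 6.7-fold lower number from compound 2 to compound 3 (0.82 log units; beyond the scatter). In this assay compound 3 is estimated at 15000 nM, with an expected range from 2000 nM to 100000 nM.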

Compound 3, concentration for 50% growth inhibition: 100000 nM
Compound 3: the middle estimate sits 6.7-fold (0.82 log units) below what was measured, within the range that was stated.
By their numbers in this assay, from the lowest: compound 1; then compounds 2 and 3 (each within the scatter of the next).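

Read in this assay, the furan attachment point on the carbonyl carbon gives no change at the digits printed from compound 2 to compound 3 (within the scatter) for this change of furan-2-yl to furan-3-yl, so the two furans cannot be told apart here. Furan-3-yl in place of thiophen-2-yl gives a 55-fold higher number from compound 1 to compound 3 (1.74 log units; beyond the scatter) and thus matches the large step already seen for furan-2-yl, which shows that this step does not depend on which furan attachment is used. Nothing shown here explains why thiophen-2-yl stands apart from both furans.

The compounds shown leave open whether thiophen-3-yl would stay with compound 1 or fall with compound 2 and compound 3. They also leave open where a phenyl ring or a pyrrol-2-yl group on the same carbonyl carbon would fall.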